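A few compounds are considered here, and "the series" means these few. Any claim that something is new, unique, unknown or untested is made for them only; others in the source may bear on it.

Measured compounds in this series:

compound 1, `C=C1C(=O)[C@]23C[C@@]1(O)CC[C@H]2c1ccc(OS(=O)(=O)c2ccc(C)cc2)c(C)c1[C@@H]3Cn1cc(-c2ccc(Cl)cc2)nn1`: 1260 nM
compound 2, `C=C1C(=O)[C@]23C[C@@]1(O)CC[C@H]2c1ccc(O)c(C)c1[C@@H]3Cn1cc(-c2ccc(F)cc2)nn1`: 660 nM
compound 3, `C=C1C[C@]23C[C@@]1(O)CC[C@@H]2c1cccc(C)c1[C@@H]3Cn1cc(-c2ccc(Br)cc2)nn1`: a limit only, > 20000 nM

The read-out throughout is a functional assay on HL-60 cells (Homo sapiens) for cytotoxicity, read by MTT assay, with a stated time of 4 days; on this read-out lower numbers stand for stronger inhibition and higher numbers for weaker inhibition. Compound 1 gives 1260 nM and compound 2 gives 660 nM in this assay. For compound 3 the assay reports no number but only a limit, > 20000 nM; compound 3 sits at the limit of > 20000 nM in this assay, at which 1 of the 3 values shown sits. Compound 3 therefore stands apart from compound 1 and compound 2 on the numbers alone, and nothing further can be read from its entry.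

The next compound, compound 4, is `C=C1C[C@]23C[C@@]1(O)CC[C@@H]2c1cccc(C)c1[C@@H]3Cn1cc(-c2ccc(F)cc2)nn1`. It differs from compound 3 in one place: fluoro in place of bromo on an aromatic carbon, para to a large group.

Going by the values given here, no pair of measured compounds differing in a single place is available, so no measured step sizes this exchange. Because compound 3 is recorded only as > 20000 nM, a halogen swap of this kind is expected to give no step beyond the scatter, a number no higher from compound 3 to compound 4 (the limit leaves the size open), and compound 4 is expected most likely to come back as a limit as well. Compound 4 is therefore estimated at 20000 nM in this assay, with a range from 8000 nM to 50000 nM.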

Compound 4, half-maximal inhibitory concentration: > 20000 nM
Compound 4: no number, only a limit (the forecaster's own chance of this, stated with the estimate: 75%); the middle value sits exactly at the limit.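

Compound 3 and compound 4 are both recorded only as limits in this assay, so no step can be read between them and the change from 4-bromophenyl to 4-fluorophenyl stays unsized. Both sit at the same limit: the limit of > 20000 nM in this assay, at which 2 of the 4 values shown sit.

The compounds shown leave open what fluoro in place of bromo does in a compound that returns a number.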